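The source may report more compounds than this note shows. Statements on the series, on what has been measured and on what is new or still open speak of the compounds shown alone.

Measured so far:

compound 1, `CC1=C(C(=O)OC2CCCC2)C(c2ccco2)NC(=O)N1`: 577 nM
compound 2, `CC1=C(C(=O)OCC2CC2)C(c2ccco2)NC(=O)N1`: 138 nM
compound 3, `CC1=C(C(=O)OC2CCCC2)C(c2ccoc2)NC(=O)N1`: 1010 nM

All three were run in an assay on membranes from HEK293 cells for displacement of a labelled ligand from adenosine receptor A2b (Homo sapiens), read by scintillation counting, with a stated time of 30 min; on this read-out higher numbers stand for weaker inhibition and lower numbers for stronger inhibition. The set is small and holds two changes. The first is an ester change, (cyclopropylmethyl in place of cyclopentyl on an oxygen next to a carbonyl group). This gives a 4.2-fold lower number from compound 1 to compound 2 (0.62 log units; beyond the scatter), a modest step that lies beyond the usual scatter. The second is a change at the core, (furan-3-yl in place of furan-2-yl on a saturated ring carbon). It gives a 1.8-fold higher number from compound 1 to compound 3 (0.24 log units; within the scatter), which lies within the scatter, so the numbers for compound 1 and compound 3 are treated as indistinguishable here. Going by the values given here, compound 2 stands apart from compound 3 as well: its number is lower by a margin beyond the scatter, while no single step between them is broken down.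

Compound 4, `CC1=C(C(=O)OCC2CC2)C(c2ccoc2)NC(=O)N1`, has not been measured. Among the compounds with values here, it differs from compound 3 by cyclopropylmethyl in place of cyclopentyl on an oxygen next to a carbonyl group, and this is the same change as the one from compound 1 to compound 2: the place lines read identically, an oxygen next to a carbonyl group whose other neighbours are the carbonyl carbon. The only thing that moves between the two pairs is the core, from furan-2-yl to furan-3-yl on the saturated ring carbon, and that core change itself produced a step within the scatter.

Within the data shown here, the expectation for compound 4 is therefore a step of about the same size as the one already seen, estimated as a 4.2-fold lower number from compound 3 to compound 4 (0.62 log units; beyond the scatter), because a 4.2-fold lower number from compound 1 to compound 2 (0.62 log units; beyond the scatter) is the only measured instance of this ester change. With one prior example only, the range is kept wide. The estimate for compound 4 in this assay is 240 nM, with a span from 100 nM to 600 nM.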

Compound 4, inhibition constant: 426 nM
Compound 4: middle estimate off by 1.8-fold (0.25 log units), on the low side; the measured number falls inside the stated range.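

In this assay the swap of cyclopentyl for cyclopropylmethyl keeps its direction on the second core, with a 2.4-fold lower number from compound 3 to compound 4 (0.37 log units; beyond the scatter), and the two steps cannot be told apart in size: the same change on two cores in this assay, a 4.2-fold lower number (0.62 log units; beyond the scatter) from compound 1 to compound 2 and a 2.4-fold lower number (0.37 log units; beyond the scatter) from compound 3 to compound 4, 1.8-fold (0.25 log units) apart, within the scatter of two such steps. The furan swap, read on the cyclopropylmethyl esters, gives a 3.1-fold higher number from compound 2 to compound 4 (0.49 log units; beyond the scatter), which lies beyond the scatter while the earlier step on the cyclopentyl esters lies within it, yet these two steps also cannot be told apart: the same change on two cores in this assay, a 1.8-fold higher number (0.24 log units; within the scatter) from compound 1 to compound 3 and a 3.1-fold higher number (0.49 log units; beyond the scatter) from compound 2 to compound 4, 1.8-fold (0.25 log units) apart, within the scatter of two such steps. Within these four compounds the two changes therefore carry from one core to the other, but two pairs per change cannot show that this would hold on any further core, and they give no reason for the carry-over.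

Left open is how far the ester change reaches beyond cyclopentyl and cyclopropylmethyl, for instance with a longer chain such as n-butyl on an oxygen next to a carbonyl group. Also open, from the compounds shown here alone, is whether a carboxylic acid in place of the ester, or an amine in place of the furan-2-yl or furan-3-yl on the saturated ring carbon, would follow the same steps.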